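The compounds below may be only part of what the source reports. "The series", "measured", "known", "first", "only" and "open" are said of these compounds alone.

In a functional assay on MT4 cells (Homo sapiens) for cytotoxicity, with a stated time of 4 days (on this read-out lower numbers stand for higher toxicity in this test and higher numbers for lower toxicity in this test), compound 1 `[N-]=[N+]=NCc1ncnc2c1ncn2[C@@H]1O[C@H](CO)[C@@H](O)[C@H]1O` gives 32000 nM. Compound 2 `OC[C@H]1O[C@@H](n2cnc3c(CSc4ccccn4)ncnc32)[C@H](O)[C@@H]1O` stands at > 100000 nM, which is a limit of the assay and not a number. In compound 3 `OC[C@H]1O[C@@H](n2cnc3c(Cn4ccc5ccccc54)ncnc32)[C@H](O)[C@@H]1O`, 1H-indol-1-yl takes the place of (pyridin-2-yl)sulfanyl on a saturated chain carbon bound to an aromatic carbon (1H-indol-1-yl in place of (pyridin-2-yl)sulfanyl on a saturated chain carbon bound to an aromatic carbon). Among the measured compounds shown here, the only measured step at this place is an at least 3.1-fold higher number from compound 1 to compound 2 (0.49 log units; beyond the scatter), and it does not involve the 1H-indol-1-yl group. Only a small move towards lower numbers is therefore expected in this assay. The estimated change is an at least 1.3-fold lower number from compound 2 to compound 3 (0.12 log units; that floor lies within the scatter). For compound 3 the expected value is 75000 nM, with an estimated range of 25000 nM to 100000 nM.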

Compound 3, half-maximal cytotoxic concentration: 45000 nM
Estimate against measurement, compound 3: 1.7-fold (0.22 log units) above, and the stated range covers the measured number.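

In this assay, the exchange at this place gives an at least 2.2-fold lower number from compound 2 to compound 3 (0.34 log units; beyond the scatter), so not every aromatic group on the saturated chain carbon bound to an aromatic carbon matches the reading of compound 2. Set against azido, 1H-indol-1-yl gives a 1.4-fold higher number from compound 1 to compound 3 (0.15 log units; within the scatter), so these two groups are not separated in this test. Compound 2 stands at a limit of the assay and not a number: the limit of > 100000 nM in this assay, at which 1 of the 3 values shown sits.

Open: how an amine or a carboxylic acid at this place would read. Three compounds also do not settle whether the sulfur atom of (pyridin-2-yl)sulfanyl matters.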